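A few compounds are considered here, and "the series" means these few. Any claim that something is new, unique, unknown or untested is made for them only; others in the source may bear on it.

Compound 1 `CC(C)(C)c1ccccc1Oc1ncccc1NC(=O)Nc1ccc(C2(CO)CC2)cc1`, compound 2 `CC(C)(C)c1ccccc1Oc1ncccc1NC(=O)Nc1ccc(N2CCCCC2)cc1` and compound 3 `CN(C)CC(C)(C)COc1ccc(NC(=O)Nc2cccnc2Oc2ccccc2C(C)(C)C)cc1` share one core and differ in a single group. In a physicochemical assay for lipophilicity, read by HPLC (a lower number here means a more polar compound, a higher number a more lipophilic compound), compound 1 gives 4.6, compound 2 gives 5.5 and compound 3 gives 5.1. Compound 3 is therefore the second highest of the three, and the gaps around it are a number 0.40 log units lower from compound 2 to compound 3 (beyond the scatter) and a number 0.50 log units higher from compound 1 to compound 3 (beyond the scatter).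

Compound 4 `CN(C)CC(C)(C)COc1ccc(NC(=O)Nc2cccnc2Oc2ccccc2[Si](C)(C)C)cc1` keeps all of compound 3 except one group: a group of 4 heavy atoms (3 carbon, 1 silicon; no ring) in place of a group of 4 heavy atoms (4 carbon; no ring), on an aromatic carbon. Among the compounds with values here, no measured step tests this swap. The nearest guide is the three steps above, together with a number 0.90 log units higher from compound 1 to compound 2 (beyond the scatter), and all of them replace a different, much larger group. They show that such replacements gave modest steps in this assay, but they say little about this much smaller change. A small rise is expected, with no step beyond the scatter, although these data do not settle its direction. The estimated step is a number 0.20 log units higher from compound 3 to compound 4 (within the scatter). For compound 4 the estimated value is 5.3, with an expected range from 4.9 to 5.7.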

Compound 4, partition coefficient: 4.7
Compound 4: the middle estimate sits 0.60 log units above what was measured; measured number below the stated range.
By their numbers in this assay, from the lowest: compounds 1 and 4 (each within the scatter of the next); then compound 3; then compound 2.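

Exchanging the tert-butyl on this aromatic carbon, ortho to a large group, for the group of 3 carbon and 1 silicon gives a number 0.40 log units lower from compound 3 to compound 4 (beyond the scatter) in this assay. The two groups match in every count computed here, with 4 heavy atoms, no ring, no hydrogen-bond donors or acceptors and no net charge, so these counts do not capture what separates them at this position, and this small exchange moves the reading as far as a number 0.40 log units lower from compound 2 to compound 3 (beyond the scatter), a change of a much larger group. Nothing available here accounts for the drop.

Going by these compounds, whether the same exchange gives a similar step when the piperidin-1-yl of compound 2 replaces the chain of compound 3 remains open. So does the reading of other groups at this position, such as isopropyl or trifluoromethyl.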